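The compounds below may be only part of what the source reports. "The series", "measured", "known", "first", "only" and "open" are said of these compounds alone.

Compound 1 `Nc1nccc(-c2c(-c3ccc(F)cc3)nn3c(NC4CCCC4)cccc23)n1`: 46000 nM
Compound 2 `Fc1ccc(-c2nn3c(NC4CCCC4)cccc3c2-c2ccnc(NC3CCCC3)c2)cc1`: > 40000 nM

Within the data shown here, in an ADME assay on Vero cells (Chlorocebus sabaeus) for cytotoxicity (a higher number here means that more compound is tolerated, a lower number that less compound is tolerated), compound 1 gives 46000 nM, the only plain number among the two values shown. For compound 2 this assay reports only a limit, > 40000 nM; this is the limit of > 40000 nM in this assay, at which 1 of the 2 values shown sits. Compound 3 `Fc1ccc(-c2nn3c(NC4CCCC4)cccc3c2-c2ccc3[nH]ccc3c2)cc1` differs from compound 1 by 1H-indol-5-yl in place of 2-aminopyrimidin-4-yl on an aromatic carbon. Among the measured compounds shown here, no step between two measured compounds covers such a change, so compound 3 is expected to sit close to compound 1 in this assay, shifted at most slightly toward less tolerated compound, as a 1.5-fold lower number from compound 1 to compound 3 (0.19 log units; within the scatter). Compound 3 is therefore estimated at 30000 nM in this assay, within 10000 nM to 80000 nM.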

Compound 3, half-maximal cytotoxic concentration: 20000 nM
Compound 3: the middle estimate sits 1.5-fold (0.18 log units) above what was measured, and the stated range covers the measured number.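

In this assay, among these compounds, this is the first step read at this position, on an aromatic carbon of a five-membered aromatic ring with 2 nitrogen: replacing 2-aminopyrimidin-4-yl with 1H-indol-5-yl gives a 2.3-fold lower number from compound 1 to compound 3 (0.36 log units; beyond the scatter). The position therefore does respond to the group it carries, with this change going toward less tolerated compound. Among the compounds shown here, compound 2 gives only a limit, and no step to it can be read: the limit of > 40000 nM in this assay, at which 1 of the 3 values shown sits.

Nothing shown tells which feature of the 1H-indol-5-yl group accounts for the step. Going by these compounds, how a morpholine or a carboxylic acid on this aromatic carbon would read also stays open.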